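Replacing a methylsulfonyl with pyrrolidin-1-yl on an imidazolium oxime

This account rests on a few compounds, and the source may have more. Where it says the series, first, only, none or still open, it means among the compounds named here.

The shared core of compound 2 `C[n+]1ccn(CCS(C)(=O)=O)c1/C=N/O` and compound 1 `C[n+]1ccn(CCOCCCl)c1/C=N/O` differs only in the group two bonds along the chain from the aromatic nitrogen. Among the measured compounds shown here, in a physicochemical assay for lipophilicity (a higher number here means a more lipophilic compound, a lower number a more polar compound), compound 2 gives -3.5, the lowest of the two numbers known, while compound 1 gives -2.32. For the measured compounds named here, the one measured step, a number 1.18 log units lower from compound 1 to compound 2 (beyond the scatter), puts the methylsulfonyl compound well below its 2-chloroethoxy partner.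

Compound 3 `C[n+]1ccn(CCN2CCCC2)c1/C=N/O` is not yet measured. Its change from compound 2 is pyrrolidin-1-yl in place of methylsulfonyl on a saturated chain carbon, two bonds along the chain from an aromatic nitrogen. Going by the values given here, the single step that bears on this change is the one from compound 1 to compound 2, which removed the methylsulfonyl in the other direction and shifted this assay by a large amount. Since compound 3 again loses the methylsulfonyl, the expectation is a move upward, but the group that enters differs from 2-chloroethoxy, so the size is uncertain and the estimate is kept wide. The estimated step is a number 0.50 log units higher from compound 2 to compound 3 (beyond the scatter). Compound 3 is therefore expected near -3, within a range from -3.8 to -2.2.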

Compound 3, distribution coefficient: -2.73
Compound 3: middle estimate off by 0.27 log units, on the low side; low and high end bracket the measured number.
By their numbers in this assay, from the lowest: compound 2; then compound 3; then compound 1.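

In this assay, pyrrolidin-1-yl on the saturated chain carbon, two bonds along the chain from an aromatic nitrogen, gives a number 0.77 log units higher from compound 2 to compound 3 (beyond the scatter) when it takes the place of methylsulfonyl, and a number 0.41 log units lower from compound 1 to compound 3 (beyond the scatter) when it takes the place of 2-chloroethoxy. With a third group now read at this place, the three compounds separate into three levels beyond the scatter, and compound 3 takes the middle one, so losing methylsulfonyl does not by itself bring a compound up to the level of compound 1, and the number depends on which group enters. Nothing available accounts for these shifts, and the numbers alone give no reason for the order of the three groups.

The compounds shown leave open where an open-chain amine such as dimethylamino, a six-membered ring such as piperidin-1-yl, or a carboxylic acid would fall in this order on the same shared core. They also leave open whether a longer chain carrying the same three groups would keep them in the same order, since all three groups have been read at this one place only.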